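Working notes on the terminal aryl substituent of the series

The source may report more compounds than this note shows. Statements on the series, on what has been measured and on what is new or still open speak of the compounds shown alone.

Measured so far:
compound 1, `O=C(Nc1cccc(-n2cc(-c3ccncc3)c(-c3ccc(Cl)c(O)c3)n2)c1)Nc1cccc(C(F)(F)F)c1`, 1060 nM
compound 2, `COc1cc(-c2nn(-c3cccc(NC(=O)Nc4ccc(Cl)c(Cl)c4)c3)cc2-c2ccncc2)ccc1Cl`, 700 nM
compound 3, `COc1cc(-c2nn(-c3cccc(NC(=O)Nc4cccc(C(F)(F)F)c4)c3)cc2-c2ccncc2)ccc1Cl`, 580 nM

All three numbers come from a functional assay on OVCAR-3 cells (Homo sapiens) for inhibition, read by sulforhodamine B assay, with a stated time of 48 h; a higher number here means a weaker inhibitor, a lower number a stronger inhibitor. Compound 3 gives the lowest of the three numbers, but neither neighbour is separated from it by more than the usual scatter: the step of a 1.2-fold lower number from compound 2 to compound 3 (0.08 log units; within the scatter) and the step of a 1.8-fold lower number from compound 1 to compound 3 (0.26 log units; within the scatter) both fall within it. So compound 3 stands at the low end of a flat set, not clearly apart from compound 1 or compound 2.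

Compound 4, `COc1cc(-c2nn(-c3cccc(NC(=O)Nc4ccc(Cl)c(C(F)(F)F)c4)c3)cc2-c2ccncc2)ccc1Cl`, has not been measured. It differs from compound 3 by chloro in place of hydrogen on an aromatic carbon. Among the compounds with values here, the only measured step that touches the same part of the molecule is the step of a 1.2-fold lower number from compound 2 to compound 3 (0.08 log units; within the scatter), which swaps one substituted phenyl on the amide-type nitrogen for another and stays within the scatter. The step of a 1.8-fold lower number from compound 1 to compound 3 (0.26 log units; within the scatter) changes a different position and is also within the scatter. Nothing seen so far suggests that adding a chloro next to the trifluoromethyl group would move the number beyond the scatter, in either direction. Compound 4 is therefore expected to give 550 nM, with a likely range of 280 nM to 1100 nM. The expected step of a 1.1-fold lower number from compound 3 to compound 4 (0.02 log units; within the scatter) is estimated to lie within the scatter.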

Compound 4, half-maximal inhibitory concentration: 890 nM
Compound 4: the middle estimate sits 1.6-fold (0.21 log units) below what was measured; low and high end bracket the measured number.
By their numbers in this assay, from the lowest: compounds 3, 2, 4 and 1 (each within the scatter of the next).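

Working from this assay, chloro on the aromatic carbon ortho to the trifluoromethyl group gives a 1.5-fold higher number from compound 3 to compound 4 (0.19 log units; within the scatter), so this position on the 3-(trifluoromethyl)phenyl ring accepts the added chloro without the number leaving the scatter. Trifluoromethyl in place of chloro, with the 4-chloro held constant, gives a 1.3-fold higher number from compound 2 to compound 4 (0.10 log units; within the scatter), which is also within the scatter, so 3,4-dichlorophenyl, 3-(trifluoromethyl)phenyl and 4-chloro-3-(trifluoromethyl)phenyl on the amide-type nitrogen cannot be told apart here, and the flat picture now covers one substituent as well as two on this ring. No supporting data bear on this result, and it is not tied to any property of the chloro or the trifluoromethyl group.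

The terminal ring groups shown carry only chloro and trifluoromethyl, so it remains open whether an amine, a carboxylic acid or a nitrile at this position would move the number beyond the scatter. As far as these compounds go, it also remains open whether the chloro step reads the same on the core of compound 1, which carries a hydroxyl where compound 4 carries a methoxy.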